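From 2-chlorophenyl to 3-chlorophenyl on an amide-type nitrogen

The source may hold more compounds than are shown below. What is called first, only, known or untested is meant among the compounds shown, and "the series" means these compounds.

Measured in a functional assay on HO8910 cells (Homo sapiens) for inhibition, read by MTT assay, with a stated time of 24 h, tested at 10 ug/mL; a higher number here means more inhibition of growth at the concentration tested, a lower number less inhibition of growth
compound 1 `O=C(O)CCCCC(CCSC(=O)c1ccccc1)SC(=O)c1ccccc1` gives "not active" (no number reported)
compound 2 `O=C(CCCCC(CCSC(=O)c1ccccc1)SC(=O)c1ccccc1)Nc1ccccc1` gives "not active" (no number reported)
compound 3 `O=C(CCCCC(CCSC(=O)c1ccccc1)SC(=O)c1ccccc1)Nc1ccccc1Cl` gives 1.33%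

Compound 3, at 1.33% in this assay, is the only one of the three with a number. Compound 4 `O=C(CCCCC(CCSC(=O)c1ccccc1)SC(=O)c1ccccc1)Nc1cccc(Cl)c1` has not yet been measured. It carries 3-chlorophenyl in place of 2-chlorophenyl on an amide-type nitrogen. Within the data shown here, no measured step bears on this change, and with compound 3 at 1.33% as the only guide, no shift beyond the scatter is expected in this assay. The estimated change is a number 1.7 percentage points higher from compound 3 to compound 4 (within the scatter), and a result without any number would be no surprise. For compound 4 the expected value is 3%, within an estimated range of 0% to 14%.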

Compound 4, percent growth inhibition at one concentration: "not active" (no number reported)
For compound 4 the study gives words and no number, so the estimate cannot be set against anything.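

Among these compounds, compound 3 has a number, but compound 4 is reported only in words, and no step between them can be read in this assay. No evidence on hand bears on this result. The compounds shown leave open whether 2-chlorophenyl and 3-chlorophenyl differ at all in this assay.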